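The compounds below may be only part of what the source reports. "The series", "measured", "known", "first", "only" and "open" are said of these compounds alone.

Three ureas built on a shared core were tested in a functional assay on Daoy cells (Homo sapiens) for cytotoxicity, read by MTT assay, with a stated time of 72 h; a higher number here means a weaker inhibitor, a lower number a stronger inhibitor. Compound 1 `COc1ccc(N(C)C(=O)N(C)c2cc(OC)c(OC)c(OC)c2)cc1` carries two methylated urea nitrogens and a methoxy on one aromatic ring. In this assay compound 1 gives only a limit, >= 125000 nM. Compound 2 `COc1cc(N(C)C(=O)N(C)c2ccc(F)cc2)cc(OC)c1OC` differs from compound 1 by fluoro in place of methoxy on an aromatic carbon. In this assay compound 2 also gives only a limit, >= 125000 nM. The step that the two limits leave unreadable from compound 1 to compound 2 therefore cannot be read, since both values sit at the limit of >= 125000 nM in this assay, at which 2 of the 3 values shown sit.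

Compound 3 `COc1ccc(NC(=O)Nc2cc(OC)c(OC)c(OC)c2)cc1` keeps both urea hydrogens; how its core differs from the core of compound 1 is not broken down here. In this assay, among the measured compounds shown here, compound 3 gives 14900 nM, the only number among the three.

Compound 4 `COc1cc(NC(=O)Nc2ccc(F)cc2)cc(OC)c1OC` differs from compound 3 by fluoro in place of methoxy on an aromatic carbon, the same change that leads from compound 1 to compound 2. For the measured compounds named here, since that earlier step could not be read, no measured step guides the expectation for compound 4. On the value of compound 3, 14900 nM, compound 4 is expected near 20000 nM, between 5000 nM and 100000 nM, and the expected step is a 1.3-fold higher number from compound 3 to compound 4 (0.13 log units; within the scatter).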

Compound 4, half-maximal inhibitory concentration: 104000 nM
Estimate against measurement, compound 4: 5.2-fold (0.72 log units) below, outside the stated range (above it).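

In this assay, putting fluoro in place of methoxy on the core of compound 3 gives a 7.0-fold higher number from compound 3 to compound 4 (0.84 log units; beyond the scatter), so on this core the change from 4-methoxyphenyl to 4-fluorophenyl weakens the compound by more than the usual scatter. This is a single step on a single core, and it does not show that the change would act the same way on any other core. The matching step on the core of compound 1 cannot be read because compound 1 and compound 2 each give only a limit, so the two cores cannot be compared: the limit of >= 125000 nM in this assay, at which 2 of the 4 values shown sit.

The compounds shown leave open how a group other than methoxy or fluoro, such as chloro, an amine or a carboxylic acid, would fare in the same place on the core of compound 3. They also leave open whether any replacement on the core of compound 1 would bring a measurable number rather than a limit.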